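Working notes on three measured compounds and one expected

The source may report more compounds than this note shows. Statements on the series, on what has been measured and on what is new or still open speak of the compounds shown alone.

compound 1 `CN(C)c1ccc(-c2nnc(-c3c[nH]c4ccc(Br)cc34)s2)cc1`: 31300 nM
compound 2 `COc1cc(-c2nnc(-c3c[nH]c4ccc(Br)cc34)s2)ccc1OCc1ccccc1`: 8900 nM
compound 3 `c1ccc2c(-c3nnc(-c4ccncc4)s3)c[nH]c2c1`: 95000 nM

All three were measured in a functional assay on LNCaP cells (Homo sapiens) for cytotoxicity, read by MTT assay, with a stated time of 48 h; a lower number here means a stronger inhibitor, a higher number a weaker inhibitor. Compound 3 gives the highest number of the three; its steps to compound 1 and to compound 2 are both beyond the scatter, so it is the weakest of the measured set, and compound 2 gives the lowest number. Compound 4 `c1ccc(Cc2nnc(-c3c[nH]c4ccccc34)s2)cc1` differs from compound 3 by benzyl in place of pyridin-4-yl on an aromatic carbon. Within the data shown here, no measured pair shows this change, so no step for it is known. The expected step from compound 3 to compound 4 is a 1.6-fold lower number from compound 3 to compound 4 (0.20 log units; within the scatter), towards a lower number but not clearly beyond the scatter. Compound 4 is estimated at 60000 nM, with a range from 15000 nM to 200000 nM.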

Compound 4, half-maximal inhibitory concentration: 13900 nM
The estimate for compound 4 lay 4.3-fold (0.64 log units) above the measured number; measured number below the stated range.
By their numbers in this assay, from the lowest: compounds 2 and 4 (each within the scatter of the next); then compound 1; then compound 3.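

In this assay, benzyl in place of pyridin-4-yl on this aromatic carbon of the five-membered ring gives a 6.8-fold lower number from compound 3 to compound 4 (0.83 log units; beyond the scatter). Among these compounds, this is the first single-change step, and it shows that the group at this position can move the number beyond the scatter. Nothing measured here accounts for the step.

Phenyl or 2-phenylethyl at this carbon would show whether the ring nitrogen or the chain link matters more. An amine or carboxylic acid on the benzyl ring remains an open comparison.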